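A few compounds are considered here, and "the series" means these few. Any claim that something is new, unique, unknown or untested is made for them only; others in the source may bear on it.

In a functional assay on the whole organism (strain Sprague-Dawley) for inhibition, with Rattus norvegicus as the target, with a stated time of 10 min (on this read-out higher numbers stand for an effect only at larger amounts of compound and lower numbers for an effect already at smaller amounts), compound 1 `CCCOc1ccccc1-c1ncc(C(=O)O)c(=O)[nH]1` gives 0.9 mg/kg, and compound 2 `CCC(C)Oc1ccccc1-c1ncc(C(=O)O)c(=O)[nH]1` gives 0.5 mg/kg; the step of a 1.8-fold lower number from compound 1 to compound 2 (0.26 log units; within the scatter) goes with methyl in place of hydrogen on a saturated chain carbon bound to an oxygen on an aromatic ring and a saturated chain carbon. Compound 3 `COc1cccc(-c2ncc(C(=O)O)c(=O)[nH]2)c1` gives 10 mg/kg in this assay, the highest of the three numbers; the difference between the core of compound 1 and the core of compound 3 is not broken down here. Compound 4 `CCOc1cccc(-c2ncc(C(=O)O)c(=O)[nH]2)c1` is not yet measured and differs from compound 3 by methyl in place of hydrogen on a saturated chain carbon bound to an oxygen on an aromatic ring. This is the same kind of change as that from compound 1 to compound 2, though there the saturated chain carbon is bound to an oxygen on an aromatic ring and a saturated chain carbon, whereas here it is bound to an oxygen on an aromatic ring. Because compound 3 gives 10 mg/kg in this assay and the earlier step of a 1.8-fold lower number from compound 1 to compound 2 (0.26 log units; within the scatter) lay within the scatter, a step of similar size is expected: a 1.4-fold lower number from compound 3 to compound 4 (0.15 log units; within the scatter). Compound 4 is estimated at 7 mg/kg, with a range from 3 mg/kg to 20 mg/kg.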

Compound 4, dose for 50% inhibition: 5 mg/kg
The estimate for compound 4 lay 1.4-fold (0.15 log units) above the measured number; low and high end bracket the measured number.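

In this assay, methyl in place of hydrogen on a saturated chain carbon bound to an oxygen on an aromatic ring goes with a 2.0-fold lower number from compound 3 to compound 4 (0.30 log units; within the scatter). Set beside the earlier step, the same change reads alike on the two cores: the same change on two cores in this assay, a 1.8-fold lower number (0.26 log units; within the scatter) from compound 1 to compound 2 and a 2.0-fold lower number (0.30 log units; within the scatter) from compound 3 to compound 4, 1.1-fold (0.05 log units) apart, within the scatter of two such steps. This shows that the change gave steps of matching size on these two pairs, but since each step lies within the scatter, it does not show a real effect on either core, nor that the match would hold on any further core.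

The compounds shown leave open whether a longer chain, such as butyl, would follow the same course on these cores. They also leave open what an amine at that place would give.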